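The source may report more compounds than this note shows. Statements on the series, on what has been measured and on what is new or still open speak of the compounds shown alone.

Three hydrazide compounds built on one shared core have been tested in an ADME assay on cells (Macrophage) for cytotoxicity, read by MTT assay, with a stated time of 24 h; on this read-out lower numbers stand for higher toxicity in this test and higher numbers for lower toxicity in this test. Compound 1 `O=C(/C=C/c1cccc(Cl)c1)NNC(=O)c1ccc2c(c1)OCCO2` gives 391000 nM, compound 2 `COc1ccccc1/C=C/C(=O)NNC(=O)c1ccc2c(c1)OCCO2` gives 312000 nM, and compound 3 `O=C(/C=C/c1ccc(F)cc1)NNC(=O)c1ccc2c(c1)OCCO2` gives 319000 nM. The three numbers sit close together: the step of a 1.3-fold lower number from compound 1 to compound 2 (0.10 log units; within the scatter), the step of a 1.2-fold lower number from compound 1 to compound 3 (0.09 log units; within the scatter) and the step of a 1.0-fold higher number from compound 2 to compound 3 (0.01 log units; within the scatter) all stay within the scatter, so compound 3 cannot be told apart from the other two on this read-out.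

Compound 4 `Cc1ccccc1/C=C/C(=O)NNC(=O)c1ccc2c(c1)OCCO2` is the next member. It differs from compound 3 by 2-methylphenyl in place of 4-fluorophenyl on a double-bonded chain carbon bound to a double-bonded chain carbon. The aromatic ring attached to the double-bonded chain has already been varied among the measured compounds, and none of those changes moved the number beyond the scatter. The change to compound 4 is of the same kind, so the expectation is a step of a 1.0-fold higher number from compound 3 to compound 4 (0.01 log units; within the scatter), that is, nothing beyond the scatter. On that basis compound 4 is estimated to give 330000 nM in this assay, with a likely range from 200000 nM to 550000 nM.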

Compound 4, half-maximal cytotoxic concentration: 268000 nM
Beside the measured number, compound 4's estimate is 1.2-fold (0.09 log units) above it, within the range that was stated.
By their numbers in this assay, from the lowest: compounds 4, 2, 3 and 1 (each within the scatter of the next).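

Putting 2-methylphenyl on a double-bonded chain carbon bound to a double-bonded chain carbon gives a 1.2-fold lower number from compound 3 to compound 4 (0.08 log units; within the scatter) in this assay, and methyl in place of methoxy on an aromatic carbon gives a 1.2-fold lower number from compound 2 to compound 4 (0.07 log units; within the scatter) on the same read-out. Even a 1.5-fold lower number from compound 1 to compound 4 (0.16 log units; within the scatter), the largest step among these four compounds, stays inside the scatter, so a substituent made of carbon alone joins fluoro, chloro and methoxy on this ring with no readable change in the number. No measurement shown here offers a reason for this flat picture.

From the compounds shown here alone, each of the four rings carries a single substituent, so it remains open whether an amine or a carboxylic acid on the ring, or a longer chain in place of methyl, would move the number beyond the scatter. Going by these compounds, it also remains open whether the number would stay this flat with a change to the shared core.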